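Replacing the Methoxycarbonyl Group of Compound 3: An Estimate

The source may hold more compounds than are shown below. What is called first, only, known or untested is meant among the compounds shown, and "the series" means these compounds.

Compound 1 `N#CC1=C(/N=C/Nc2ccc([N+](=O)[O-])cc2)N(c2ccccc2)C(=O)N2CCCCC(N3CCCC3)C12`: 32.1%
Compound 2 `N#CC1=C(/N=C/Nc2ccccc2)N(c2ccccc2)C(=O)N2CCCCC(N3CCCC3)C12`: 35.2%
Compound 3 `COC(=O)C(=O)NC1=C(C#N)C2C(N3CCCC3)CCCCN2C(=O)N1c1ccccc1`: 69.2%

In a functional assay on the whole organism (strain albino) for inhibition, with Rattus norvegicus as the target, read by paw edema, with a stated time of 1 h, at a dose of 20 mmol/kg by the intraperitoneal route (on this read-out lower numbers stand for less inhibition and higher numbers for more inhibition at the one dose given (going by the name of the read-out)), compound 3 gives 69.2%, the highest of the three, with compound 2 nearest and compound 1 furthest, as the steps of a number 34 percentage points higher from compound 2 to compound 3 (beyond the scatter) and a number 37.1 percentage points higher from compound 1 to compound 3 (beyond the scatter) show. Compound 4 `N#CC1=C(NC(=O)c2ccccc2O)N(c2ccccc2)C(=O)N2CCCCC(N3CCCC3)C12` differs from compound 3 by 2-hydroxyphenyl in place of methoxycarbonyl on a carbonyl carbon. Among the compounds with values here, no measured step alters that part of compound 3 alone; the two large steps towards compound 3 each exchanged the whole group on the double-bonded ring carbon, and in both the group without a ring carried the higher number. Compound 4 brings an aromatic ring back into that side chain, so a modest downward step, a number 11.2 percentage points lower from compound 3 to compound 4 (beyond the scatter), is expected. Compound 4 is estimated at 58%, within 38% to 78%.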

Compound 4, a percentage reported as inhibition, in the whole organism at one dose (the size of the read-out at that dose, not a potency): 44.7%
The estimate for compound 4 lay 13.3 percentage points above the measured number; the range from low to high includes it.
By their numbers in this assay, from the lowest: compounds 1, 2 and 4 (each within the scatter of the next, the first and the last beyond it); then compound 3.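

In this assay, exchanging only the group on the carbonyl carbon gave a number 24.5 percentage points lower from compound 3 to compound 4 (beyond the scatter), so the value of compound 3 does not survive 2-hydroxyphenyl in place of methoxycarbonyl. Against the other ring-bearing side chains, the result is a number 9.5 percentage points higher from compound 2 to compound 4 (within the scatter) and a number 12.6 percentage points higher from compound 1 to compound 4 (beyond the scatter), which places compound 4 within the scatter of one and beyond that of the other. Nothing measured accounts for this step.

As far as these compounds go, whether a carboxylic acid or ethoxycarbonyl on that carbonyl carbon would hold the value of compound 3 remains open. So does the effect of an unsubstituted phenyl there.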